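A few compounds are considered here, and "the series" means these few. Any claim that something is new, unique, unknown or untested is made for them only; others in the source may bear on it.

Working notes on the series in a functional assay on CHO-K1 cells for antagonist activity at Orexin receptor type 2 (Homo sapiens), read by FLIPR and calcium flux; on this read-out lower numbers stand for stronger inhibition and higher numbers for weaker inhibition.

Compound 1 `CCOC(=O)c1ccccc1C(=O)N1C[C@H](Oc2cc(C#N)ccn2)CC[C@H]1C` gives 21 nM. Compound 2 `CC(C)OC(=O)c1ccccc1C(=O)N1C[C@H](Oc2cc(C#N)ccn2)CC[C@H]1C`, which carries a methyl in place of hydrogen on a saturated chain carbon bound to an oxygen next to a carbonyl group and a saturated chain carbon, gives 38 nM; the step of a 1.8-fold higher number from compound 1 to compound 2 (0.26 log units; within the scatter) is within the scatter. Compound 3 `C#Cc1ccnc(O[C@@H]2CC[C@@H](C)N(C(=O)c3ccccc3-n3nccn3)C2)c1` gives 10 nM, the lowest of the three numbers, beyond the scatter from compound 1 and further still from compound 2.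

Compound 4 `C[C@@H]1CC[C@@H](Oc2cc(-c3ccccc3)ccn2)CN1C(=O)c1ccccc1-n1nccn1` is not yet measured. It differs from compound 3 by phenyl in place of ethynyl on an aromatic carbon, on an aromatic carbon of a six-membered aromatic ring with 1 nitrogen, meta to a large group and opposite the ring nitrogen. Within the data shown here, the only measured step, from compound 1 to compound 2, concerns the ester side and does not touch this ring, so no measured step bears on the change. The expectation for compound 4 therefore rests on compound 3 alone: a step of a 2.5-fold higher number from compound 3 to compound 4 (0.40 log units; beyond the scatter) is estimated, a modest rise with wide uncertainty. Compound 4 is expected at about 25 nM, between 6 nM and 100 nM.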

Compound 4, half-maximal inhibitory concentration: 45 nM
The estimate for compound 4 lay 1.8-fold (0.26 log units) below the measured number, within the range that was stated.
By their numbers in this assay, from the lowest: compound 3; then compounds 1, 2 and 4 (each within the scatter of the next, the first and the last beyond it).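

In this assay, among these compounds, phenyl in place of ethynyl on the aromatic carbon opposite the ring nitrogen gives a 4.5-fold higher number from compound 3 to compound 4 (0.65 log units; beyond the scatter), the first measured step at this position. The position therefore still gives a measurable number with a six-carbon aromatic ring in place of a two-carbon triple-bonded group, though the rise lies beyond the scatter. No measurement at hand accounts for this rise, so it stays unexplained.

A single pair cannot show whether the rise follows from the added atoms or from the aromatic ring itself, and a cyclopropyl or a methoxy group at the same place would separate the two. Also open, going by these compounds, is whether the same change gives a similar step on the ester-bearing amide of compound 1.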